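A few compounds are considered here, and "the series" means these few. Any claim that something is new, unique, unknown or untested is made for them only; others in the source may bear on it.

Measured so far:
compound 1, `CC(=O)OC/C1=C/C[C@](C)(CCC=C(C)C)/C=C/[C@@H](OC(=O)C=C(C)C)[C@](C)(OC(C)=O)/C=C/C1=O`, gives 3990 nM in a functional assay on MCF7 cells (Homo sapiens) for antiproliferative activity, read by MTT assay, with a stated time of 48 h; on this read-out higher numbers stand for weaker inhibition and lower numbers for stronger inhibition
compound 2, `CC(C)=CCC[C@]1(C)/C=C/[C@@H](OC(=O)C=C(C)C)[C@](C)(O)/C=C/C(=O)/C(CN(C)C)=C\C1`, gives 690 nM

Compound 2 holds the lower of the two numbers; compound 1 sits a step beyond the scatter above it. Compound 3, `CCN(CC)C(=O)/C1=C/C[C@](C)(CCC=C(C)C)/C=C/[C@@H](OC(=O)C=C(C)C)[C@](C)(O)/C=C/C1=O`, awaits measurement and differs from compound 2 in one place: diethylcarbamoyl in place of (dimethylamino)methyl on a double-bonded ring carbon. For the measured compounds named here, no measured pair isolates this exchange, so the two values alone guide the guess. The hydroxy group of compound 2 is kept, so only a modest weakening is expected, with the step of a 2.2-fold higher number from compound 2 to compound 3 (0.34 log units; beyond the scatter) expected to sit near the edge of the scatter. Compound 3 is estimated at 1500 nM, within 400 nM to 5000 nM.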

Compound 3, half-maximal inhibitory concentration: 12100 nM
Compound 3: middle estimate off by 8.1-fold (0.91 log units), on the low side; measured number outside the range, above it.
By their numbers in this assay, from the lowest: compound 2; then compound 1; then compound 3.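

In this assay, diethylcarbamoyl in place of (dimethylamino)methyl on the double-bonded ring carbon gives an 18-fold higher number from compound 2 to compound 3 (1.24 log units; beyond the scatter) with the hydroxy group kept, so the group on this carbon strongly shapes the read-out. Both groups count the same hydrogen-bond donors and acceptors and no net charge, so these counts do not separate the pair. No measurement on hand explains the step.

Going by these compounds, the exchange alters the carbonyl and the alkyl groups on nitrogen together, and their separate shares remain open. Dimethylcarbamoyl or (diethylamino)methyl on this carbon would separate them.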